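Series notes: side-group exchange and half-life outlook

The source may report more compounds than this note shows. Statements on the series, on what has been measured and on what is new or still open speak of the compounds shown alone.

Two compounds share one core and differ only in the group on a saturated chain carbon bound to an aromatic carbon and a saturated chain carbon. Compound 1 `CC(C)C(c1ccc(-c2ccc3cccc(F)c3c2)[nH]c1=O)N1CCCCC1=O` carries 2-oxopiperidin-1-yl there; in an ADME assay on microsomes from liver (Homo sapiens) for metabolic stability (a lower number here means that the compound disappears faster, a higher number that the compound lasts longer), compound 1 gives 0.183 h. Compound 2 `CC(C)C(Nc1nccs1)c1ccc(-c2ccc3cccc(F)c3c2)[nH]c1=O` carries (1,3-thiazol-2-yl)amino; in this assay compound 2 gives 0.17 h. The step of a 1.1-fold lower number from compound 1 to compound 2 (0.03 log units; within the scatter) leaves the two numbers indistinguishable; compound 2 holds the lower of the two figures, but the gap sits inside the scatter.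

Compound 3 `CC(C)C(Cc1nnn[nH]1)c1ccc(-c2ccc3cccc(F)c3c2)[nH]c1=O` is not yet measured. The change is (1H-tetrazol-5-yl)methyl in place of (1,3-thiazol-2-yl)amino on a saturated chain carbon bound to an aromatic carbon and a saturated chain carbon. Among the compounds with values here, the single measured step at this position, a 1.1-fold lower number from compound 1 to compound 2 (0.03 log units; within the scatter), swapped one group for a quite different one without moving the half-life beyond the scatter; it is the only step that bears on the new exchange, and it is a thin basis. Nothing else in the numbers points either way. The expected step is therefore no change at the digits printed from compound 2 to compound 3 (within the scatter), within the scatter. Compound 3 is estimated at 0.17 h, with a range of 0.08 h to 0.4 h.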

Compound 3, half-life: > 3 h
Compound 3: a limit, no number (the forecaster's own chance of this, stated with the estimate: 5%); middle value at least 17-fold (1.24 log units) away from the limit.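

Exchanging (1,3-thiazol-2-yl)amino for (1H-tetrazol-5-yl)methyl on this saturated chain carbon gives an at least 17-fold higher number from compound 2 to compound 3 (1.24 log units; beyond the scatter), and the exchange from 2-oxopiperidin-1-yl gives an at least 16-fold higher number from compound 1 to compound 3 (1.21 log units; beyond the scatter), so a position that showed only a 1.1-fold lower number from compound 1 to compound 2 (0.03 log units; within the scatter) in the earlier pair can move the half-life in this assay well past the scatter. The counts do not separate the two groups of the first exchange, since they match in heavy atoms, ring size, hydrogen-bond donors, hydrogen-bond acceptors and net charge; they differ in the hetero atoms of the ring, sulfur and nitrogen against nitrogen alone, and in the link, an amino nitrogen against a methyl carbon. The figure for compound 3 is a limit of the assay and not a number, so the full size of both steps stays unknown: the limit of > 3 h in this assay, at which 1 of the 3 values shown sits.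

The compounds shown leave open whether the change follows the tetrazole ring or the methyl link, a question that (1,3-thiazol-2-yl)methyl or (1H-tetrazol-5-yl)amino on the same carbon would settle. They also leave open whether a carboxylic acid carried on a methyl link at this carbon would track (1H-tetrazol-5-yl)methyl in this assay.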